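Swapping methyl for fluoro in compound 2

The source may report more compounds than this note shows. Statements on the series, on what has been measured and on what is new or still open speak of the compounds shown alone.

In a functional assay on MCF7 cells (Homo sapiens) for antiproliferative activity, read by MTT assay, with a stated time of 24 h (a higher number here means a weaker inhibitor, a lower number a stronger inhibitor), compound 1 (`FC(F)(F)c1ccc(-c2nn(-c3ccccc3)cc2-c2nc3ccccc3[nH]2)cc1`) gives 6330 nM as its value, while compound 2 (`Cc1ccc(-c2nn(-c3ccccc3)cc2-c2nc3ccccc3n2S(=O)(=O)c2ccc(C)cc2)cc1`) gives 570 nM as the lower of the two numbers, making it the stronger inhibitor by a gap beyond the scatter. Compound 3 (`Cc1ccc(-c2nn(-c3ccccc3)cc2-c2nc3ccccc3n2S(=O)(=O)c2ccc(F)cc2)cc1`), not yet measured, differs from compound 2 by fluoro in place of methyl on an aromatic carbon in one place: fluoro in place of methyl on an aromatic carbon, para to a large group. Among the measured compounds shown here, no measured pair shows this change, so only a small move is expected, with a 1.1-fold higher number from compound 2 to compound 3 (0.02 log units; within the scatter) estimated to stay within the scatter. The expected value for compound 3 is 600 nM (range 220 nM to 1600 nM).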

Compound 3, half-maximal inhibitory concentration: 5270 nM
For compound 3 the middle estimate is 8.8-fold (0.94 log units) below the measured one; the measured number lies above the stated range.
By their numbers in this assay, from the lowest: compound 2; then compounds 3 and 1 (each within the scatter of the next).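

In this assay, exchanging (4-methylphenyl)sulfonyl for (4-fluorophenyl)sulfonyl gives a 9.2-fold higher number from compound 2 to compound 3 (0.97 log units; beyond the scatter). So this position is sensitive: replacing a single heavy atom, with no change in ring, donor or acceptor count, moves the number well beyond the scatter. No measurement shown explains why the move is this large.

On these data alone, whether methyl is special here remains open, since a chloro, methoxy or ethyl group at this place could separate the two readings. Also open, as far as these compounds go, is whether the same swap on the other 4-methylphenyl group of compound 2 would have a similar effect.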